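A few compounds are considered here, and "the series" means these few. Any claim that something is new, unique, unknown or untested is made for them only; others in the source may bear on it.

Measured in an ADME assay on the whole organism (Rattus norvegicus) for pharmacokinetics, using cassette dosing, at a dose of 1 mg/kg by the oral route; on this read-out higher numbers stand for higher oral bioavailability and lower numbers for lower oral bioavailability:
- Compound 1 `C[C@@H](Cn1c(=O)[nH]/c(=N\c2ccc(Oc3nccs3)cc2)n(Cc2ccc(Cl)cc2)c1=O)C(=O)O`: 41.4%
- Compound 2 `C[C@@H](Cn1c(=O)[nH]/c(=N\c2ccc(Oc3ccccn3)cc2)n(Cc2ccc(Cl)cc2)c1=O)C(=O)O`: 52.8%

Compound 2 holds the higher of these two numbers, and the gap to compound 1 lies beyond the scatter. The next compound, compound 3 `C[C@@H](Cn1c(=O)[nH]/c(=N\c2ccc(Oc3ccsn3)cc2)n(Cc2ccc(Cl)cc2)c1=O)C(=O)O`, departs from compound 2 at a single place, on an oxygen on an aromatic ring: 1,2-thiazol-3-yl in place of pyridin-2-yl on an oxygen on an aromatic ring. For the measured compounds named here, only one measured step bears on this change: a number 11.4 percentage points higher from compound 1 to compound 2 (beyond the scatter). That step put pyridin-2-yl in place of 1,3-thiazol-2-yl, and it was modest but beyond the scatter. The present change runs the other way, from pyridin-2-yl to a different thiazolyl group, 1,2-thiazol-3-yl. Going by the values given here, no measured compound carries that group, so a single step offers only loose guidance. A fall in this assay is therefore expected, similar in size to the measured step or somewhat smaller. Estimated on this basis, the expected change is a number 8.8 percentage points lower from compound 2 to compound 3 (within the scatter). For compound 3 the estimated value is 44%, with an expected range from 30% to 58%.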

Compound 3, oral bioavailability in the Rattus norvegicus assay: 87.6%
The estimate for compound 3 lay 43.6 percentage points below the measured number; the measured number lies above the stated range.
By their numbers in the Rattus norvegicus assay, from the lowest: compound 1; then compound 2; then compound 3.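

Placed on the oxygen, 1,2-thiazol-3-yl and 1,3-thiazol-2-yl are far from interchangeable in the Rattus norvegicus assay, with a number 46.2 percentage points higher from compound 1 to compound 3 (beyond the scatter), so the presence of a thiazolyl group alone does not settle the outcome at this position. Pyridin-2-yl, the better of the two groups compared earlier, is itself overtaken in the Rattus norvegicus assay, with a number 34.8 percentage points higher from compound 2 to compound 3 (beyond the scatter), which shows that the earlier step gave no fair guide to a different thiazolyl group. The same change runs the opposite way in a physicochemical assay for solubility, at pH 1.2 (a higher number here means a more soluble compound, a lower number a less soluble compound), so higher oral bioavailability here comes with much lower solubility: the measured solubility of compound 2, 31.5 ug/mL, and of compound 3, 0.8 ug/mL, a 39-fold lower number (1.60 log units; beyond the scatter) In the physicochemical assay compound 2 gives 31.5 ug/mL and compound 3 gives 0.8 ug/mL.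

The compounds shown leave open whether the gain belongs to 1,2-thiazol-3-yl alone or would also appear with another five-membered ring on the oxygen, such as oxazolyl or pyrazolyl, and whether a methyl or a chlorine on the 1,2-thiazol-3-yl ring would keep it. They also do not tell why oral bioavailability and solubility part in this way, or whether the same order would hold if an amide replaced the carboxylic acid.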